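Epimer Step from Compound 2 to Compound 3

A few compounds are considered here, and "the series" means these few. Any claim that something is new, unique, unknown or untested is made for them only; others in the source may bear on it.

Within the data shown here, the two compounds measured so far are compound 1 `O=C(O)[C@H]1NC[C@@H](O)[C@H](O)[C@@H]1O` and compound 2 `O=C(O)[C@@H]1NC[C@@H](O)[C@H](O)[C@H]1O`. In an assay for inhibition of alpha-N-acetylgalactosaminidase (Gallus gallus), tested at 1000 uM (a higher number here means more inhibition at the concentration tested (going by the name of the read-out), a lower number less inhibition), compound 1 gives 11%, and compound 2 gives 1.3%. Compound 2 stands lowest of the two numbers, with compound 1 its nearest neighbour; the step of a number 9.7 percentage points lower from compound 1 to compound 2 (within the scatter) lies within the scatter, so the two are not distinguished, even though (the fact that compounds 1 and 2 differ only in the configuration as drawn). Compound 3 `O=C(O)[C@@H]1NC[C@H](O)[C@H](O)[C@H]1O` has not yet been measured. The change is the two compounds have the same atoms and bonds and differ only in configuration as drawn: 1 of 4 stereo elements differ; a stereocentre at a saturated ring carbon is drawn R in compound 2 and S in compound 3. Among the measured compounds shown here, the only measured step that bears on such a change is the one from compound 1 to compound 2, which altered two stereocentres and gave a difference within the scatter; a single stereocentre change is therefore expected to give no step beyond the scatter in this assay. The step from compound 2 to compound 3 is expected to be a number 2.7 percentage points higher from compound 2 to compound 3 (within the scatter). For compound 3 the estimated inhibition is 4%, with a range from 0% to 15%.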

Compound 3, a percentage reported as inhibition, at one concentration (the size of the read-out at that concentration, not a potency): 4.4%
Compound 3: the middle estimate sits 0.4 percentage points below what was measured; the measured number falls inside the stated range.
By their numbers in this assay, from the lowest: compounds 2, 3 and 1 (each within the scatter of the next).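

In this assay, among these compounds, inverting a single stereocentre at a saturated ring carbon, drawn R in compound 2 and S in compound 3, gives a number 3.1 percentage points higher from compound 2 to compound 3 (within the scatter), so this one centre alone produces no step that can be told from the scatter. Changing three of the four stereo elements together gives a number 6.6 percentage points lower from compound 1 to compound 3 (within the scatter), so the earlier finding for two changed elements now also holds for one and for three. All three compounds therefore stand within the scatter of one another, and the one change at this position is purely one of configuration: the fact that compounds 2 and 3 differ only in the configuration as drawn

On these data alone, what stays open is whether any configuration in this set matters in this assay at all, as none of the three stands apart. As far as these compounds go, it is also open whether a methyl ester in place of the carboxylic acid, or a longer chain on the amine, would give a step beyond the scatter.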